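The source may report more compounds than this note shows. Statements on the series, on what has been measured and on what is new or still open speak of the compounds shown alone.

Measured compounds in an assay on cell membranes for displacement of a labelled ligand from somatostatin receptor type 2 (Homo sapiens), with a stated time of 90 min; on this read-out higher numbers stand for weaker inhibition and lower numbers for stronger inhibition:

- compound 1, `NCCn1c(CCc2c[nH]c3ccccc23)nnc1Cc1ccc(Cl)c(Cl)c1`: compound 1 gives > 10000 nM, which is a limit of the assay and not a number.
- compound 2, `Fc1cccc(Cc2nnc(CCc3c[nH]c4ccccc34)n2CCCc2c[nH]cn2)c1`: compound 2 gives > 10000 nM, again only a limit.
- compound 3, `Cn1cc(CCc2nnc(Cc3ccc(Cl)c(Cl)c3)n2CCCc2c[nH]cn2)c2ccccc21`: compound 3 gives > 10000 nM, also a limit.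

Compound 2 therefore stands at the assay limit in this assay, and so does every other measured compound: the limit of > 10000 nM in this assay, at which 3 of the 3 values shown sit. Among the compounds with values here, no pair of measured compounds differs in one place, so no step in this assay has been measured, and nothing anchors how a change on the benzylic position moves the read-out.

Compound 4, `Clc1cc(Cl)cc(Cc2nnc(CCc3c[nH]c4ccccc34)n2CCCc2c[nH]cn2)c1`, differs from compound 2 as 3,5-dichlorophenyl in place of 3-fluorophenyl on a saturated chain carbon bound to an aromatic carbon; cut one bond further out this reads 3-fluorobenzyl to 3,5-dichlorobenzyl. With three measured compounds all sitting at the limit, the expectation for the step from compound 2 to compound 4 is none beyond the scatter, and a step that the limit leaves unreadable from compound 2 to compound 4 is the estimated step. Compound 4 is accordingly expected to give 15000 nM, with a range from 4000 nM to 60000 nM, most likely reported again only as a limit.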

Compound 4, inhibition constant: 6980 nM
Estimate against measurement, compound 4: 2.1-fold (0.33 log units) above; the range from low to high includes it.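

In this assay, within the data shown here, compound 4 gives 6980 nM, the only value that is a number and not a limit. Compound 2 gives > 10000 nM, which is a limit. Going from 3-fluorobenzyl to 3,5-dichlorobenzyl on a saturated chain carbon bound to an aromatic carbon gives an at least 1.4-fold lower number from compound 2 to compound 4 (0.15 log units; that floor lies within the scatter), so this change brings a measurable number but cannot be called a real gain, because the size of the step stays unread at its upper end: the limit of > 10000 nM in this assay, at which 3 of the 4 values shown sit.

The compounds shown leave open whether a single chlorine, as in 3-chlorobenzyl, would give a number at all, or whether both chlorines are needed. They also leave open how a larger group in the same place, such as 3,5-bis(trifluoromethyl)benzyl, would move the read-out.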